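Sulfanyl for benzylamino on the shared core

A few compounds are considered here, and "the series" means these few. Any claim that something is new, unique, unknown or untested is made for them only; others in the source may bear on it.

Compound 3 `Nc1cc(N)c2nc(-c3ccccc3)c(NCc3ccc(F)cc3)nc2c1` carries a (4-fluorobenzyl)amino group on the shared core. In a functional assay on OVCAR-3 cells (Homo sapiens) for inhibition, read by sulforhodamine B assay, with a stated time of 48 h (on this read-out higher numbers stand for lower toxicity in this test and lower numbers for higher toxicity in this test), compound 3 gives only a limit, < 100000 nM, and no number. Its two measured neighbours differ from it in one place each: compound 1 `Nc1cc(N)c2nc(-c3ccccc3)c(Oc3ccc(Cl)c(Cl)c3)nc2c1`, with 3,4-dichlorophenoxy in place of that group, gives 66100 nM in this assay, and compound 2 `COc1ccc(CNc2nc3cc(N)cc(N)c3nc2-c2ccccc2)cc1OC`, with 3,4-dimethoxyphenyl on the saturated chain carbon bound to a nitrogen on the aromatic ring, gives 8510 nM. Both steps into compound 3, a step that the limit leaves unreadable from compound 1 to compound 3 and a step that the limit leaves unreadable from compound 2 to compound 3, stay unreadable in size and direction owing to the limit of < 100000 nM in this assay, at which 1 of the 3 values shown sits.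

Compound 4 `COc1ccc(Sc2nc3cc(N)cc(N)c3nc2-c2ccccc2)cc1` is the next step: (4-methoxyphenyl)sulfanyl in place of (4-fluorobenzyl)amino on an aromatic carbon. Going by the values given here, no measured step reads on this change, so the expectation rests on the span that the measured substituents at this carbon have covered, from the value of compound 1 to that of compound 2, with the position of compound 3 inside that span left open by its limit. The estimated step is a step that the limit leaves unreadable from compound 3 to compound 4, its direction not readable from the data. Compound 4 is expected to give about 30000 nM in this assay, with a range from 8000 nM to 100000 nM.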

Compound 4, concentration lethal to 50% of the cells: < 100000 nM
Compound 4 ended at the assay's limit; the forecaster's own chance of this, stated with the estimate: 30%; the middle value does not contradict the limit.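

No new step can be read from compound 4, whether against compound 3 or against compound 1, in this assay; both comparisons stop at a limit: the limit of < 100000 nM in this assay, at which 2 of the 4 values shown sit.

The compounds shown leave open how (4-methoxyphenyl)sulfanyl, (4-fluorobenzyl)amino and 3,4-dichlorophenoxy rank against one another on this aromatic carbon of the shared core.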